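The compounds below may be only part of what the source reports. "The series", "measured", "known", "first", "only" and "open" are said of these compounds alone.

Measured in a functional assay (Homo sapiens) for antiproliferative activity; a lower number here means a stronger inhibitor of growth, a higher number a weaker inhibitor of growth:
- compound 1 `Cc1sc2nc(-c3ccncc3)c(/C=N/NC(=N)N)n2c1C`: 95500 nM
- compound 2 `Cc1sc2nc(-c3ccccn3)c(/C=N/NC(=N)N)n2c1C`: 83200 nM
- compound 3 `N=C(N)N/N=C/c1c(-c2ccccn2)nc2sc(Cl)cn12`: 13200 nM

Compound 3 has the lowest number of the three, and its gaps to compound 1 and compound 2 both lie beyond the scatter. Next is compound 4 `N=C(N)N/N=C/c1c(-c2ccncc2)nc2sc(Cl)cn12`, with pyridin-4-yl in place of pyridin-2-yl on an aromatic carbon.

Within the data shown here, the only measured step that bears on this is the same exchange in the opposite direction on a different core, a 1.1-fold lower number from compound 1 to compound 2 (0.06 log units; within the scatter), which lies within the scatter. Going by these compounds, whether it transfers to the core of compound 3 is untested. No change beyond the scatter is therefore expected in this assay, and the expected step is a 1.1-fold higher number from compound 3 to compound 4 (0.06 log units; within the scatter). The estimated value for compound 4 is 15000 nM, with an expected range of 7000 nM to 32000 nM.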

Compound 4, concentration for total growth inhibition: 11700 nM
Compound 4: middle estimate off by 1.3-fold (0.11 log units), on the high side, within the range that was stated.
By their numbers in this assay, from the lowest: compounds 4 and 3 (each within the scatter of the next); then compounds 2 and 1 (each within the scatter of the next).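

On the core of compound 3, the exchange of pyridin-2-yl for pyridin-4-yl on this aromatic carbon gives no change beyond the scatter in this assay, with a 1.1-fold lower number from compound 3 to compound 4 (0.05 log units; within the scatter). The exchange has now been read on two cores, and it stays within the scatter on both, so the two steps agree: the same change on two cores in this assay, a 1.1-fold lower number (0.06 log units; within the scatter) from compound 1 to compound 2 and a 1.1-fold higher number (0.05 log units; within the scatter) from compound 4 to compound 3, 1.3-fold (0.11 log units) apart, within the scatter of two such steps

Only these two pyridinyl groups are shown at this position, so the position's tolerance for other groups remains unknown. Pyridin-3-yl, phenyl or a phenyl ring carrying an amine could still shift the number in this assay.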